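This account rests on a few compounds, and the source may have more. Where it says the series, first, only, none or still open, it means among the compounds named here.

Working notes on the series, a functional assay on NCI-H460 cells (Homo sapiens) for inhibition, read by MTT assay, with a stated time of 72 h; a lower number here means a stronger inhibitor, a higher number a weaker inhibitor. Compound 1 `COc1cc2c(Oc3ccc(NC(=O)c4nn(-c5ccccc5OC(F)(F)F)c(=O)cc4C)cc3F)ccnc2cc1OCCCN1CCN(C)CC1` gives 260 nM. Among the compounds with values here, compound 2 `COc1ccc(-n2nc(C(=O)Nc3ccc(Oc4ccnc5cc(OCCCN6CCN(C)CC6)c(OC)cc45)c(F)c3)c(C)cc2=O)cc1` gives 3660 nM; the single change between them, a 4-methoxyphenyl in place of a 2-(trifluoromethoxy)phenyl on an aromatic nitrogen, reads as a 14-fold higher number from compound 1 to compound 2 (1.15 log units; beyond the scatter). Compound 3 `COc1cc2c(Oc3ccc(NC(=O)c4nn(-c5ccc(Cl)cc5)c(=O)cc4C)cc3F)ccnc2cc1OCCCN1CCCC1` gives 360 nM, the second highest of the three numbers, within the scatter of compound 1 and well apart from compound 2.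

Compound 4 `COc1cc2c(Oc3ccc(NC(=O)c4nn(-c5ccc(Cl)cc5)c(=O)cc4C)cc3F)ccnc2cc1OCCCN1CCN(C)CC1` has not yet been measured. It differs from compound 3 only at the end of the chain: 4-methylpiperazin-1-yl in place of pyrrolidin-1-yl on a saturated chain carbon, three bonds along the chain from an oxygen on an aromatic ring. Within the data shown here, no measured step tests this exchange directly. Among the measured compounds shown here, the one measured step, the change on the aromatic nitrogen from compound 1 to compound 2, touches another part of the molecule and says nothing about the chain terminus. Compound 1 already carries the 4-methylpiperazin-1-yl end, and its value sits within the scatter of compound 3, but those two compounds also differ on the aromatic nitrogen, so only their two values can be compared, not the exchange alone. The expectation is therefore a step of a 1.1-fold lower number from compound 3 to compound 4 (0.05 log units; within the scatter), that is, nothing beyond the scatter. Compound 4 is expected at 320 nM, in the range 130 nM to 800 nM.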

Compound 4, half-maximal inhibitory concentration: 440 nM
Estimate against measurement, compound 4: 1.4-fold (0.14 log units) below; the range from low to high includes it.
By their numbers in this assay, from the lowest: compounds 1, 3 and 4 (each within the scatter of the next); then compound 2.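

In this assay the exchange on a saturated chain carbon, three bonds along the chain from an oxygen on an aromatic ring, now has a direct test with 4-chlorophenyl on the aromatic nitrogen (a 1.2-fold higher number from compound 3 to compound 4 (0.09 log units; within the scatter)), and pyrrolidin-1-yl and 4-methylpiperazin-1-yl cannot be told apart in this pair. With 4-methylpiperazin-1-yl held constant, the group on the aromatic nitrogen still matters: chloro in place of methoxy on an aromatic carbon gives a step beyond the scatter (an 8.3-fold lower number from compound 2 to compound 4 (0.92 log units; beyond the scatter)), while 4-chlorophenyl in place of 2-(trifluoromethoxy)phenyl stays within it (a 1.7-fold higher number from compound 1 to compound 4 (0.23 log units; within the scatter)), so compound 2 stands apart from compound 1 and compound 4, which cannot be separated from each other. Nothing available offers an explanation for any of these results.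

Pyrrolidin-1-yl appears here only with 4-chlorophenyl on the aromatic nitrogen, so whether the two chain ends also match with 2-(trifluoromethoxy)phenyl or 4-methoxyphenyl there remains open. The compounds shown also leave open how a morpholin-4-yl group, an open-chain dimethylamino group or a longer chain would read in this assay.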